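The source may report more compounds than this note shows. Statements on the series, on what has been measured and on what is new or still open speak of the compounds shown alone.

Measured in a functional assay on HCT-116 cells (Homo sapiens) for antiproliferative activity, read by MTT assay, with a stated time of 68 h (a higher number here means a weaker inhibitor, a lower number a stronger inhibitor), each value a limit and not a number:
- compound 1 `O=S(=O)(Nc1ccc(F)c(C#Cc2cnc3[nH]ncc3c2)c1F)c1ccccc1`: > 10000 nM
- compound 2 `O=S(=O)(Nc1ccc(F)c(C#Cc2cnc3[nH]ncc3c2)c1F)c1ccccn1`: > 10000 nM
- compound 3 `O=S(=O)(Nc1ccc(F)c(C#Cc2cnc3[nH]ncc3c2)c1F)c1cccnc1`: > 10000 nM

Compound 3 has only a limit, > 10000 nM. For the measured compounds named here, the series so far stands at the limit of > 10000 nM in this assay, at which 3 of the 3 values shown sit.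

Compound 4 `O=S(=O)(Nc1ccc(F)c(C#Cc2cnc3[nH]nc(C4CC4)c3c2)c1F)c1cccnc1` carries cyclopropyl in place of hydrogen on an aromatic carbon.

The measured steps all lie on the sulfonyl sulfur, not at this carbon: a step that the two limits leave unreadable from compound 1 to compound 2, a step that the two limits leave unreadable from compound 1 to compound 3, a step that the two limits leave unreadable from compound 2 to compound 3. None gives a size to carry over, so any expectation in this assay rests on a series without a readable number.

Expected, with low confidence, is an at least 1.4-fold lower number from compound 3 to compound 4 (0.15 log units; that floor lies within the scatter), towards a stronger inhibitor if a number is reported at all.

The estimate for compound 4 is 7000 nM, with an expected range of 1500 nM to 10000 nM.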

Compound 4, half-maximal inhibitory concentration: 584 nM
For compound 4 the middle estimate is 12-fold (1.08 log units) above the measured one; measured number outside the range, below it.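

Cyclopropyl in place of hydrogen on this aromatic carbon gives the only readable step in this assay: an at least 17-fold lower number from compound 3 to compound 4 (1.23 log units; beyond the scatter). This position therefore moves the series off its limit, which the changes on the sulfonyl sulfur did not do, and those steps cannot be read. Compound 4 alone carries a number, and the remaining compounds stay at a limit: the limit of > 10000 nM in this assay, at which 3 of the 4 values shown sit.

On these data alone, whether cyclopropyl gives a similar step with phenyl or pyridin-2-yl on the sulfonyl sulfur stays open. Also open, as far as these compounds go, is how methyl, a longer chain or an amine would compare with cyclopropyl at this carbon.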